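Defining the stereocentre of a fluorinated chromanone

The source may report more compounds than this note shows. Statements on the series, on what has been measured and on what is new or still open speak of the compounds shown alone.

Measured compounds:
compound 1, `O=C1C[C@H](c2ccc(F)cc2)Oc2cc(F)ccc21`: 150 nM
compound 2, `Cc1ccc(C2CC(=O)c3ccc(F)cc3O2)cc1`: 160 nM

Of the compounds shown here, two sharing one core have been measured in an in vitro assay on BTI-TN-5B1-4 cells for inhibition of Amine oxidase [flavin-containing] B (Homo sapiens); a higher number here means a weaker inhibitor, a lower number a stronger inhibitor. Compound 1 gives 150 nM, and compound 2 gives 160 nM. Of these two numbers, that of compound 2 stands at the top, its nearest neighbour being compound 1, whose number lies within the scatter of it; the two values therefore show no difference that can be read as a real one.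

The account now turns to compound 3, `Cc1ccc([C@H]2CC(=O)c3ccc(F)cc3O2)cc1`, which has not yet been measured in this assay. Compound 3 differs from compound 2 in a single respect: the two compounds have the same atoms and bonds; at least one stereo element is drawn with a configuration in one of them and without one in the other: 1 of 1 stereo elements differ; a stereocentre at a saturated ring carbon is drawn without a configuration in compound 2 and R in compound 3. Nothing leaves and nothing enters; only the drawn configuration at the saturated ring carbon is new.

For the measured compounds named here, with no pair of measured compounds differing in this way, the direction of the step cannot be read from the data. Compound 3 is expected to show a 1.5-fold lower number from compound 2 to compound 3 (0.16 log units; within the scatter) in this assay, a step that may fall within the scatter or somewhat beyond it in either direction. Compound 3 is estimated at 110 nM, with a range from 40 nM to 400 nM.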

Compound 3, half-maximal inhibitory concentration: 150 nM
Estimate against measurement, compound 3: 1.4-fold (0.13 log units) below; measured number inside the range.
By their numbers in this assay, from the lowest: compounds 1, 3 and 2 (each within the scatter of the next).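

In this assay, drawing the saturated ring carbon with the R configuration gives a 1.1-fold lower number from compound 2 to compound 3 (0.03 log units; within the scatter), so the drawn configuration alone brings no readable difference at this centre. For the compounds shown here, the pair also allows the first single-place reading of the aromatic substituent. Compounds 1 and 2 could not give this reading, as they differ in the drawn configuration as well. Methyl in place of fluoro on an aromatic carbon gives no change at the digits printed from compound 1 to compound 3 (within the scatter), and this exchange likewise leaves the number within the scatter. The reading of the first step rests on one plain fact: the fact that one of compounds 2 and 3 is drawn with a defined configuration and the other without, at the place where they differ.

The compounds shown leave open how a compound drawn with the S configuration at the saturated ring carbon would stand against compound 3, a comparison that no pair here provides. They also leave open whether this aromatic carbon stays as undemanding with a methoxy group, an amine or a carboxylic acid in place of the methyl or fluoro, since these two groups alone offer no view of the limits of the position.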